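Extending the Chain in a Cholesterol Acyltransferase Inhibitor Series

The source may hold more compounds than are shown below. What is called first, only, known or untested is meant among the compounds shown, and "the series" means these compounds.

Of the compounds shown here, two sharing one core have been tested. Compound 1 `Cc1cc(C)c(NC(=O)C(C)(C)CCCc2ccc(CC(C)C)cc2)c2c1CC(C)(C)O2` gives, in an assay for inhibition of acyl-CoA:cholesterol acyltransferase (Oryctolagus cuniculus), using microsomes (on this read-out lower numbers stand for stronger inhibition and higher numbers for weaker inhibition), a value of 40 nM. Among the measured compounds shown here, compound 2 `Cc1cc(C)c(NC(=O)C(C)(C)CCCCOc2ccc(Cl)cc2)c2c1CC(C)(C)O2` gives in this assay 330 nM, the highest of the two numbers; the only neighbour is compound 1, and the step of an 8.3-fold higher number from compound 1 to compound 2 (0.92 log units; beyond the scatter) separates them. The next compound, compound 3 `Cc1cc(C)c(NC(=O)C(C)(C)CCCCCOc2ccc(Cl)cc2)c2c1CC(C)(C)O2`, differs from compound 2 only in chain length: (4-chlorophenoxy)methyl in place of 4-chlorophenoxy on a saturated chain carbon, five bonds along the chain from a carbonyl carbon. For the measured compounds named here, no measured step concerns a change of this kind; the single measured step replaced one aromatic end group by another rather than lengthening the chain, so it offers no direct guide. Adding one chain carbon is a small change, and the expectation is a step of a 1.1-fold lower number from compound 2 to compound 3 (0.04 log units; within the scatter) that stays within the scatter. Compound 3 is therefore estimated to give 300 nM in this assay, with a range from 100 nM to 900 nM.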

Compound 3, half-maximal inhibitory concentration: 150 nM
Estimate against measurement, compound 3: 2.0-fold (0.30 log units) above, and the stated range covers the measured number.
By their numbers in this assay, from the lowest: compound 1; then compound 3; then compound 2.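

In this assay, the step of a 2.2-fold lower number from compound 2 to compound 3 (0.34 log units; beyond the scatter) shows that chain length alone matters at this position, since the 4-chlorophenoxy end group stays the same and only one chain carbon is added; the earlier step could not show this, as it also exchanged the end group. The longer chain does not close the whole gap to the 4-isobutylphenyl compound, as the step of a 3.8-fold higher number from compound 1 to compound 3 (0.57 log units; beyond the scatter) still lies beyond the scatter. No measurement shown here explains why the number responds to chain length.

As far as these compounds go, a single lengthening fixes no trend, so whether a still longer chain would lower the number further or raise it again remains open. Also open, from the compounds shown here alone, is how an amine or a carboxylic acid at the far end of the chain would read in this assay.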